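The source may hold more compounds than are shown below. What is called first, only, known or untested is meant among the compounds shown, and "the series" means these compounds.

Values in a functional assay on A549 cells (Homo sapiens) for cytotoxicity, read by MTT assay; on this read-out lower numbers stand for stronger inhibition and higher numbers for weaker inhibition:
- compound 1 `COC(=O)C[C@H]1C[C@H](O)[C@@H](C)[C@@H](c2ccc(OC)cc2)N1`: 5400 nM
- compound 2 `COc1ccc([C@H]2N[C@@H](CCO)C[C@H](O)[C@H]2C)cc1`: 17600 nM

Compound 2 holds the higher of the two numbers, and its gap to compound 1 lies beyond the scatter. The next compound is compound 3 `COc1ccc([C@H]2N[C@@H](CC(=O)O)C[C@H](O)[C@H]2C)cc1`. Its difference from compound 2 is carboxy in place of hydroxymethyl on a saturated chain carbon bound to a saturated ring carbon. Among the compounds with values here, the one measured step at this place is a 3.3-fold higher number from compound 1 to compound 2 (0.51 log units; beyond the scatter), a modest step, with hydroxymethyl in place of methoxycarbonyl. Within the data shown here, no measured compound carries carboxy, so that step gives only a rough scale. On that scale, no large change is expected in this assay, with a slight lean towards a higher number. The expected change is a 1.4-fold higher number from compound 2 to compound 3 (0.15 log units; within the scatter). Compound 3 is estimated at 25000 nM, with an expected range of 8000 nM to 70000 nM.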

Compound 3, half-maximal inhibitory concentration: 20100 nM
Estimate against measurement, compound 3: 1.2-fold (0.09 log units) above; measured number inside the range.
By their numbers in this assay, from the lowest: compound 1; then compounds 2 and 3 (each within the scatter of the next).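

In this assay, carboxy and hydroxymethyl on a saturated chain carbon bound to a saturated ring carbon cannot be told apart, with a 1.1-fold higher number from compound 2 to compound 3 (0.06 log units; within the scatter). Methoxycarbonyl is the group that stands apart: the step to carboxy gives a 3.7-fold higher number from compound 1 to compound 3 (0.57 log units; beyond the scatter), about the same size as the step to hydroxymethyl, so among these three compounds only compound 1 is set off beyond the scatter. Nothing available explains why this group differs from the other two.

Still open, going by these compounds, is whether an ethyl ester, an amide or an amine at this place would group with methoxycarbonyl or with the carboxy and hydroxymethyl pair. Also open, on these data alone, is whether a longer chain carrying carboxy or hydroxymethyl would stay level with compound 2 and compound 3.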